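From phenyl to 5-methylthiophen-2-yl in a cell toxicity test

The compounds below may be only part of what the source reports. "The series", "measured", "known", "first", "only" and "open" are said of these compounds alone.

- Compound 1 `CC1Cn2cc([N+](=O)[O-])nc2O1`: > 500000 nM (a limit)
- Compound 2 `CC1Cn2c(nc([N+](=O)[O-])c2Br)O1`: 9190 nM
- Compound 3 `CC1Cn2c(nc([N+](=O)[O-])c2-c2ccccc2)O1`: > 500000 nM (a limit)

All three compounds were tested in an ADME assay on CHO cells (Cricetulus griseus) for cytotoxicity, read by MTT assay, with a stated time of 24 h (on this read-out lower numbers stand for higher toxicity in this test and higher numbers for lower toxicity in this test), and share one core. Compound 3 reads > 500000 nM there, which is a limit and not a number.

Compound 4 `Cc1ccc(-c2c([N+](=O)[O-])nc3n2CC(C)O3)s1` carries 5-methylthiophen-2-yl in place of phenyl on an aromatic carbon and has not yet been measured.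

Two measured steps at this same carbon are large, and both involve the bromo compound. Bromo replacing hydrogen gave an at least 54-fold lower number from compound 1 to compound 2 (1.73 log units; beyond the scatter) and phenyl replacing bromo gave an at least 54-fold higher number from compound 2 to compound 3 (1.73 log units; beyond the scatter) on the same scale. Phenyl replacing hydrogen gave a step that the two limits leave unreadable from compound 1 to compound 3 and so adds no size. Among the measured compounds shown here, compound 3 is the only measured compound with an aromatic ring at this carbon, so the guide is thin. Bromo is absent from compound 4, so no large fall is expected, only a modest one at most. The expected step is an at least 1.4-fold lower number from compound 3 to compound 4 (0.15 log units; that floor lies within the scatter) in the direction of a lower number, if a number is reported at all. The reading may again be only a limit. For compound 4 the estimated value is 350000 nM, with an expected range from 60000 nM to 500000 nM in this test.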

Compound 4, half-maximal cytotoxic concentration: > 125000 nM
Compound 4 was reported as a limit; the forecaster's own chance of this, stated with the estimate: 55%; the middle value lies beyond the limit too.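

In this assay compound 4 gives > 125000 nM, which is a limit and not a number. Replacing bromo with 5-methylthiophen-2-yl gives an at least 13-fold higher number from compound 2 to compound 4 (1.13 log units; beyond the scatter), so a five-membered aromatic ring with a sulfur atom at this carbon also leaves the low number of the bromo compound far behind, as the six-membered phenyl ring of compound 3 did. The steps from compound 1 and from compound 3 to compound 4 cannot be read, since each has a limit at both ends: the limit of > 125000 nM in this assay, at which 1 of the 4 values shown sits.

Whether phenyl and 5-methylthiophen-2-yl differ at all in this test stays open, since the two compounds without a number to compare against compound 4 share a different limit: the limit of > 500000 nM in this assay, at which 2 of the 4 values shown sit. The compounds shown also leave open how a group with no aromatic ring, such as an amine or a carboxylic acid, would read at this carbon in this assay, and whether chloro would bring the same large fall in the number as bromo.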